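Exchanging the aryl group on a ring nitrogen

The source may report more compounds than this note shows. Statements on the series, on what has been measured and on what is new or still open speak of the compounds shown alone.

Compound 1 `Nc1scc(CN2CCN(c3cccc(C(F)(F)F)c3)CC2)c1C(=O)c1ccc(Cl)cc1`: -8.2%
Compound 2 `Nc1scc(CN2CCN(c3ccccc3C(F)(F)F)CC2)c1C(=O)c1ccc(Cl)cc1`: 0%
Compound 3 `Nc1scc(CN2CCN(c3c(F)cccc3F)CC2)c1C(=O)c1ccc(Cl)cc1`: -12%

These three compounds share one core and differ only in the aryl group carried by a ring nitrogen. In a functional assay on CHO cells with adenosine receptor A1 (Homo sapiens) as the target, read by cAMP accumulation and immunoassay, with a stated time of 6 min, tested at 0.01 uM (a higher number here means a weaker effect of the compound at the concentration tested, a lower number a stronger effect), compound 1 gives -8.2%, the second highest of the three numbers; its nearest neighbour is compound 3 and its furthest is compound 2, and both of those differences lie within the scatter, so the three compounds read as essentially alike at the concentration tested.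

Compound 4 `Nc1scc(CN2CCN(c3cc(Cl)ccc3Cl)CC2)c1C(=O)c1ccc(Cl)cc1` keeps the core and changes the same group: 2,5-dichlorophenyl in place of 3-(trifluoromethyl)phenyl on an amine nitrogen in a ring. Two measured steps start from compound 1 and alter exactly this group. The first is a number 8.2 percentage points higher from compound 1 to compound 2 (within the scatter); the second is a number 3.8 percentage points lower from compound 1 to compound 3 (within the scatter). Neither moved the read-out beyond the scatter, although the entering groups were quite different from each other. Among the compounds with values here, the one step beyond the scatter, a number 12 percentage points lower from compound 2 to compound 3 (beyond the scatter), is modest and does not begin at compound 1. The expectation for compound 4 in this assay is therefore no step beyond the scatter, and a number 0.2 percentage points higher from compound 1 to compound 4 (within the scatter) is the estimated change. Compound 4 is expected to give about -8%, between -22% and 6%.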

Compound 4, a percentage reported as activity, at one concentration (the size of the read-out at that concentration, not a potency): 13%
For compound 4 the middle estimate is 21 percentage points below the measured one; the measured number lies above the stated range.
By their numbers in this assay, from the lowest: compounds 3, 1 and 2 (each within the scatter of the next, the first and the last beyond it); then compound 4.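

In this assay, within the data shown here, the 2,5-dichlorophenyl group is the first aryl group on this ring nitrogen to stand apart from all the others in the set, with every step to compound 4 beyond the scatter, though modest in size (a number 21.2 percentage points higher from compound 1 to compound 4 (beyond the scatter); a number 25 percentage points higher from compound 3 to compound 4 (beyond the scatter); a number 13 percentage points higher from compound 2 to compound 4 (beyond the scatter)). This makes compound 4 the compound with the weakest effect of the four at the concentration tested, and it shows that the read-out at this position does respond to the aryl group, even though the steps from compound 1 to compounds 2 and 3 stayed within the scatter. Nothing available explains why this exchange behaves differently from the earlier ones.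

Compound 4 is the only compound here with chlorine on this aryl group, so the compounds shown cannot tell whether one chlorine would be enough or whether both are needed, as a plain 2-chlorophenyl or 3-chlorophenyl group would show. They also leave open how an aryl group bearing a methoxy group, an amine or a carboxylic acid would read at this position, and, with a single concentration as the read-out, how these compounds differ in potency.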